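Iodo to ethynyl: next step in the series

The source may hold more compounds than are shown below. What is called first, only, known or untested is meant among the compounds shown, and "the series" means these compounds.

In a functional assay on SK-OV-3 cells (Homo sapiens) for antiproliferative activity, read by MTT assay, with a stated time of 72 h (on this read-out higher numbers stand for weaker inhibition and lower numbers for stronger inhibition), compound 1 `O=C(CCc1cccc2c1B(O)OC2)Nc1ccccc1` gives 200 nM and compound 2 `O=C(CCc1cccc2c1B(O)OC2)Nc1cccc(I)c1` gives 630 nM, the higher of the two numbers. Compound 3 `C#Cc1cccc(NC(=O)CCc2cccc3c2B(O)OC3)c1` follows from compound 2 by ethynyl in place of iodo on an aromatic carbon, with ethynyl in place of iodo on an aromatic carbon. Going by the values given here, the one measured step that bears on this carbon is a 3.2-fold higher number from compound 1 to compound 2 (0.50 log units; beyond the scatter), a modest step. Among the compounds with values here, no ethynyl compound has been measured yet, so only a small move towards a lower number in this assay, within the scatter, is expected. The expected step is a 1.5-fold lower number from compound 2 to compound 3 (0.18 log units; within the scatter). For compound 3 the estimated value is 420 nM, with an expected range of 170 nM to 1000 nM.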

Compound 3, half-maximal inhibitory concentration: 980 nM
Estimate against measurement, compound 3: 2.3-fold (0.37 log units) below; low and high end bracket the measured number.
By their numbers in this assay, from the lowest: compound 1; then compounds 2 and 3 (each within the scatter of the next).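

Ethynyl cannot be told apart from iodo on this carbon, meta to a large group, with a 1.6-fold higher number from compound 2 to compound 3 (0.19 log units; within the scatter) in this assay as the only direct comparison. Against hydrogen the change is clear, with a 4.9-fold higher number from compound 1 to compound 3 (0.69 log units; beyond the scatter) showing that compound 3, like compound 2, stands apart from compound 1 at this position. No data at hand account for this result.

From the compounds shown here alone, whether fluoro, an amine or a carboxylic acid on this carbon would stay close to compound 1 remains open. So does whether iodo and ethynyl would behave alike elsewhere on this ring.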